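This account rests on a few compounds, and the source may have more. Where it says the series, first, only, none or still open, it means among the compounds named here.

Compound 1, `O=C(Nc1cccc(-c2oc3cc(-c4ccc(F)cc4)ccc3c(=O)c2O)c1)c1ccc(F)cc1`, gives 9280 nM in a functional assay on HepG2 cells (Homo sapiens) for antiproliferative activity, read by CCK-8 assay, with a stated time of 72 h; on this read-out lower numbers stand for stronger inhibition and higher numbers for weaker inhibition. Compound 2, `O=C(Nc1cccc(-c2oc3cc(-c4ccc(F)cc4)ccc3c(=O)c2O)c1)c1ccc(Br)cc1`, gives 13900 nM in the same assay.

Among the measured compounds shown here, on these two numbers compound 2 stands highest, its nearest neighbour being compound 1: the step of a 1.5-fold higher number from compound 1 to compound 2 (0.18 log units; within the scatter) is the only measured step, and it lies within the scatter. Compound 3, `COc1cccc(C(=O)Nc2cccc(-c3oc4cc(-c5ccc(F)cc5)ccc4c(=O)c3O)c2)c1`, is not yet measured. It differs from compound 2 in one place: 3-methoxyphenyl in place of 4-bromophenyl on a carbonyl carbon.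

For the measured compounds named here, the one measured step bears on this change only loosely, since it too alters the ring on the carbonyl carbon of the amide, a swap of halogen for halogen that left the number essentially unchanged. The change to compound 3 is larger in kind, trading a halogen for a methoxy group and moving the substituent to another position of that ring, so the single step shown offers no firm direction. On this basis no step beyond the scatter is expected in this assay, with a wide range to allow for the untested group. Compound 3 is therefore estimated at 11000 nM, between 3500 nM and 35000 nM. Going by the values given here, the step this estimate means is a 1.3-fold lower number from compound 2 to compound 3 (0.10 log units; within the scatter), and it is expected to stay near the numbers measured so far.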

Compound 3, half-maximal inhibitory concentration: 9950 nM
For compound 3 the middle estimate is 1.1-fold (0.04 log units) above the measured one; low and high end bracket the measured number.
By their numbers in this assay, from the lowest: compounds 1, 3 and 2 (each within the scatter of the next).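

In this assay, the ring on the carbonyl carbon of the amide has now been varied by more than a swap of halogen: 3-methoxyphenyl in place of 4-bromophenyl gives a 1.4-fold lower number from compound 2 to compound 3 (0.15 log units; within the scatter), and 3-methoxyphenyl in place of 4-fluorophenyl gives a 1.1-fold higher number from compound 1 to compound 3 (0.03 log units; within the scatter). The entering group brings oxygen and a hydrogen-bond acceptor, which the halogenated rings lack, and its substituent stands at a different position on the ring, yet all three compounds remain within the scatter of one another, so this change shows no measurable effect on the read-out. Nothing available here accounts for this flat result.

On these data alone, every group at this position is still a substituted phenyl ring, so it remains open whether an amine, a carboxylic acid or a saturated ring such as cyclohexyl on the carbonyl carbon would read differently. The step to compound 3 also alters the substituent and its ring position together, so these compounds cannot separate the contribution of either one.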